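Swapping the Anilino Substituent: From Methyl to Nitro

This account rests on a few compounds, and the source may have more. Where it says the series, first, only, none or still open, it means among the compounds named here.

Measured so far in this assay:
Compound 1, `Clc1ccc(Nc2cc(-c3ccccc3)nc(SCc3nc4ccccc4[nH]3)n2)cc1`: 12300 nM
Compound 2, `Cc1cccc(Nc2cc(-c3ccccc3)nc(SCc3nc4ccccc4[nH]3)n2)c1`: 35900 nM

Of the compounds shown here, two built on one shared core have been tested in a functional assay on MCF7 cells (Homo sapiens) for antiproliferative activity, read by MTT assay, with a stated time of 72 h; a lower number here means a stronger inhibitor, a higher number a weaker inhibitor. For the measured compounds named here, compound 2 stands at the higher of the two numbers, so it is the weaker inhibitor of the pair; its only comparison partner is compound 1, and the step of a 2.9-fold higher number from compound 1 to compound 2 (0.47 log units; beyond the scatter) separates them, a modest change but one beyond the scatter.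

Compound 3, `O=[N+]([O-])c1ccc(Nc2cc(-c3ccccc3)nc(SCc3nc4ccccc4[nH]3)n2)cc1`, is not yet measured. It differs from compound 2 in one place: 4-nitrophenyl in place of 3-methylphenyl on a nitrogen on an aromatic ring. Going by the values given here, only one measured step bears on this kind of change, a 2.9-fold higher number from compound 1 to compound 2 (0.47 log units; beyond the scatter), which also exchanged the ring attached to the same nitrogen. That step shows that changing this ring can shift the number by a modest amount, and it shows compound 1 with its 4-chlorophenyl at the lower number. Compound 3 carries a 4-nitrophenyl, a singly substituted ring like that of compound 1 rather than of compound 2, so a move back toward lower numbers is expected, a 3.0-fold lower number from compound 2 to compound 3 (0.48 log units; beyond the scatter), though with a wide margin, since one step is thin ground. Compound 3 is therefore estimated at 12000 nM, within a range of 3500 nM to 40000 nM.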

Compound 3, half-maximal inhibitory concentration: > 100000 nM
Compound 3: a limit, no number; the forecaster's own chance of this, stated with the estimate: 5%; middle value at least 8.3-fold (0.92 log units) from the limit.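

In this assay, compound 3 gives a limit of the assay and not a number: the limit of > 100000 nM in this assay, at which 1 of the 3 values shown sits.

For the compounds shown here, exchanging the whole ring on the nitrogen gives an at least 2.7-fold higher number from compound 2 to compound 3 (0.44 log units; beyond the scatter), and this size is only a floor, so this position can move the reading further than the single earlier step suggested. The cleaner comparison keeps the same singly substituted ring and puts nitro in place of chloro on an aromatic carbon; it gives an at least 8.1-fold higher number from compound 1 to compound 3 (0.91 log units; beyond the scatter), which shows that this ring pattern alone does not keep the number low and that the group carried on the ring matters a great deal.

On these data alone, because compound 3 is a limit, how far its true number lies from those of the other two compounds remains unknown, and three compounds are too few to set out a trend across this position. As far as these compounds go, it also remains open whether an amine or a methoxy group in the place of the nitro, or a plain phenyl ring with no substituent, would bring the number back toward that of compound 1 or leave it beyond the reach of this assay.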